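This account rests on a few compounds, and the source may have more. Where it says the series, first, only, none or still open, it means among the compounds named here.

Three related compounds have been measured in a functional assay on MCF7 cells (Homo sapiens) for cytotoxicity, read by MTT assay, with a stated time of 72 h, tested at 30 uM (a higher number here means more inhibition of growth at the concentration tested, a lower number less inhibition of growth), all sharing a thiosemicarbazone-type scaffold in which a thiocarbonyl carbon carries a cyclic amine. Compound 1 `N/C(=N\NC(=S)N1CCOCC1)c1ccccn1` bears a morpholin-4-yl group and an unsubstituted pyridine and gives 78.1%. Compound 2 `N/C(=N\NC(=S)N1CCCC1)c1ccc(F)cn1` carries a pyrrolidin-1-yl group together with a fluorine on the pyridine and gives 60.6%. Compound 3 `N/C(=N\NC(=S)N1CCSCC1)c1ccc(F)cn1` keeps that fluorine and has a thiomorpholin-4-yl group; in this assay compound 3 gives 58.8%, the lowest of the three numbers, with compound 2 within the scatter and compound 1 beyond it.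

Within the data shown here, the one measured step that speaks to ring swaps on the thiocarbonyl carbon is a number 1.8 percentage points lower from compound 2 to compound 3 (within the scatter), a step within the scatter. The change to compound 4 `N/C(=N\NC(=S)N1CCOCC1)c1ccc(F)cn1` is morpholin-4-yl in place of thiomorpholin-4-yl on a thiocarbonyl carbon. Among the measured compounds shown here, compounds 1 and 4 share the morpholin-4-yl group but differ in the fluorine, a pair for which no step has been measured, so the size of that effect is unknown. Given the small ring-swap step from compound 2 to compound 3, a modest increase is expected, a number 6.2 percentage points higher from compound 3 to compound 4 (within the scatter). Compound 4 is therefore estimated at 65%, within 50% to 80%.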

Compound 4, percent growth inhibition at one concentration: 56.7%
Beside the measured number, compound 4's estimate is 8.3 percentage points above it, and the stated range covers the measured number.
By their numbers in this assay, from the lowest: compounds 4, 3 and 2 (each within the scatter of the next); then compound 1.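

In this assay, morpholin-4-yl on a thiocarbonyl carbon gives a number 2.1 percentage points lower from compound 3 to compound 4 (within the scatter) and, set against pyrrolidin-1-yl, a number 3.9 percentage points lower from compound 2 to compound 4 (within the scatter), so with the fluorine in place, all three rings give numbers within the scatter of one another. The fluorine now has a measured pair of its own: fluoro in place of hydrogen on an aromatic carbon gives a number 21.4 percentage points lower from compound 1 to compound 4 (beyond the scatter), a step beyond the scatter, and among these compounds this is the one change in a single place that moves the number by more than the scatter. No independent measurement is available that could explain either the flat ring swaps or the larger fluorine step.

Among these compounds, compound 1 is the only compound here with hydrogen on that aromatic carbon, so it remains open whether the ring on the thiocarbonyl carbon would matter more in the absence of the fluorine. Also open, on these data alone, is how a chlorine atom or a methoxy group on that aromatic carbon, or an open-chain dimethylamino group on the thiocarbonyl carbon, would compare.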